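Replacing (1,3-thiazol-2-yl)amino with piperazin-1-yl on a shared core

The compounds below may be only part of what the source reports. "The series", "measured", "known", "first", "only" and "open" are said of these compounds alone.

Compound 1 `N#Cc1c(Nc2ccccn2)nc(SCc2nc3ccccc3[nH]2)nc1-c1ccccc1` gives 8.9 nM
Compound 2 `N#Cc1c(Nc2nccs2)nc(SCc2nc3ccccc3[nH]2)nc1-c1ccccc1` gives 8.9 nM

In a functional assay on SK-MEL-28 cells (Homo sapiens) for cytotoxicity, read by MTT assay, with a stated time of 3 days (a lower number here means a stronger inhibitor, a higher number a weaker inhibitor), compound 2 stands at 8.9 nM and so is level with compound 1 at 8.9 nM in the digits given. Compound 3 `N#Cc1c(-c2ccccc2)nc(SCc2nc3ccccc3[nH]2)nc1N1CCNCC1` has not yet been measured. Among the measured compounds shown here, its one structural change is piperazin-1-yl in place of (1,3-thiazol-2-yl)amino on an aromatic carbon and it sits on an aromatic carbon, ortho to a cyano group.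

For the measured compounds named here, only one measured step bears on this: no change at the digits printed from compound 1 to compound 2 (within the scatter) with 1,3-thiazol-2-yl in place of pyridin-2-yl on a nitrogen. That step lies within the scatter, but it swapped one aromatic ring for another. Here a six-membered non-aromatic ring enters, and no measured compound holds such a group at this place. The measured step is therefore a weak guide, and the data give no firm direction.

Compound 2 at 8.9 nM already sits low, so a moderate weakening is the cautious expectation. The expected step in this assay is a 2.8-fold higher number from compound 2 to compound 3 (0.45 log units; beyond the scatter) and it is uncertain. Compound 3 is estimated at 25 nM with an expected range from 4 nM to 150 nM in this test.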

Compound 3, half-maximal inhibitory concentration: 2.6 nM
Beside the measured number, compound 3's estimate is 9.6-fold (0.98 log units) above it, and the stated range ends above it.
By their numbers in this assay, from the lowest: compound 3; then compounds 1 and 2 (each within the scatter of the next).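

In this assay, this place on an aromatic carbon, ortho to a cyano group, does not need an aromatic ring attached through an amino nitrogen: piperazin-1-yl, a six-membered non-aromatic ring, gives a 3.4-fold lower number from compound 2 to compound 3 (0.53 log units; beyond the scatter) and, set against (pyridin-2-yl)amino, gives a 3.4-fold lower number from compound 1 to compound 3 (0.53 log units; beyond the scatter). Among the compounds shown here, the earlier pair exchanged only one aromatic ring for another, with no change at the digits printed from compound 1 to compound 2 (within the scatter), so it showed that the assay accepts either of those two rings but not that this place would respond to a change in the kind of group, which it now does, modestly and towards a stronger inhibitor. Nothing shown here gives a reason for this gain.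

The change alters two things at once, since the amino link and the aromatic ring both leave together, and these compounds cannot separate the effect of one from the other. A morpholin-4-yl ring, a 4-methylpiperazin-1-yl ring or an open-chain group such as dimethylamino at the same place would show whether the ring's second nitrogen and its hydrogen matter for the lower number.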